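The compounds below may be only part of what the source reports. "The series", "measured", "known", "first", "only" and "open" are said of these compounds alone.

Compound 1 `Cc1c(Cc2ccccc2)c(=O)oc2cc(OCC(O)CNCc3ccccc3)ccc12` gives > 100000 nM in an ADME assay on A549 cells (Homo sapiens) for cytotoxicity, read by CellTiter-Glo (on this read-out lower numbers stand for higher toxicity in this test and higher numbers for lower toxicity in this test), a limit of the assay rather than a number.
Compound 2 `Cc1cc(=O)oc2cc(OCC(O)CN3CCC(C(N)=O)CC3)ccc12` gives > 100000 nM in this assay, again a limit of the assay.

Compound 2 therefore stands at the limit of > 100000 nM in this assay, at which 2 of the 2 values shown sit, and no number separates the two measured compounds. Compound 3 `Cc1c(Cc2cccc3ccccc23)c(=O)oc2cc(OCC(O)CN3CCC(C(N)=O)CC3)ccc12` differs from compound 2 in one place: (naphthalen-1-yl)methyl in place of hydrogen on an aromatic carbon. No measured step of this kind is shown, so the direction can only be guessed. The expected step of an at least 1.4-fold lower number from compound 2 to compound 3 (0.15 log units; that floor lies within the scatter) in this assay is small and toward higher toxicity, with a fair chance of another limit. Compound 3 is estimated at 70000 nM, within 20000 nM to 200000 nM.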

Compound 3, half-maximal cytotoxic concentration: 42400 nM
Beside the measured number, compound 3's estimate is 1.7-fold (0.22 log units) above it; low and high end bracket the measured number.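

At this position, two atoms from the ring oxygen, (naphthalen-1-yl)methyl in place of hydrogen moves the read-out in this assay toward higher toxicity, with an at least 2.3-fold lower number from compound 2 to compound 3 (0.37 log units; beyond the scatter). This is the only number shown that is not a limit, so the position can affect this read-out. The full size of the step stays unknown, since it starts from a limit of the assay: the limit of > 100000 nM in this assay, at which 2 of the 3 values shown sit.

Still open, as far as these compounds go, is whether a simple ethyl group or a pyridinylmethyl group at this position, with the side chain of compound 2 kept, would lower the number too.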